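Silyl Ether Series: Expectation for a Demethoxylated Analogue

The compounds below may be only part of what the source reports. "The series", "measured", "known", "first", "only" and "open" are said of these compounds alone.

Measured so far:
compound 1, `COc1ccc(C2=C(c3cc(OC)c(OC)c(OC)c3)C(=O)CC2O[SiH2]C(C)(C)C)cc1OC`: > 100 ug/mL
compound 2, `COc1ccc(C2=C(c3cc(OC)c(OC)c(OC)c3)C(=O)C(O[SiH2]C(C)(C)C)C2)cc1OC(C)C`: 7.5 ug/mL

In an ADME assay on KB cells (Homo sapiens) for cytotoxicity, read by MTT assay, with a stated time of 72 h (a lower number here means a stronger inhibitor, a higher number a weaker inhibitor), compound 1 gives only > 100 ug/mL, a limit of the assay rather than a number. In this assay compound 2 gives 7.5 ug/mL; compound 2 differs from compound 1 in more than one place, so its value is noted without a step. Of the two values shown, compound 1 sits at the limit of > 100 ug/mL in this assay, at which 1 of the 2 values shown sits.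

The next compound, compound 3, `COc1ccc(C2=C(c3cc(OC)c(OC)c(OC)c3)C(=O)CC2O[SiH2]C(C)(C)C)cc1`, differs from compound 1 by hydrogen in place of methoxy on an aromatic carbon. Within the data shown here, no step between measured compounds touches this change, so any expectation rests on compound 1 alone, and compound 1 supplies only a limit. With one end open, the size of the step from compound 1 to compound 3 in this assay cannot be drawn from the numbers; the expectation is for a step of modest size, toward a stronger inhibitor, perhaps not beyond the scatter, which the estimate an at least 1.6-fold lower number from compound 1 to compound 3 (0.22 log units; that floor lies within the scatter) expresses. On that basis compound 3 is expected in this assay at 60 ug/mL, within 15 ug/mL to 100 ug/mL, with a fair chance that only a limit is reported again.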

Compound 3, half-maximal inhibitory concentration: > 100 ug/mL
Compound 3 ended at the assay's limit; the forecaster's own chance of this, stated with the estimate: 45%; middle value at least 1.6-fold (0.22 log units) away from the limit.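

In this assay compound 1 and compound 3 both stand only at a limit of the assay, so no step can be read for hydrogen in place of methoxy: the limit of > 100 ug/mL in this assay, at which 2 of the 3 values shown sit.

The compounds shown leave open how large the change from 3,4-dimethoxyphenyl to 4-methoxyphenyl is in this assay, and in which direction it runs.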